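The source may hold more compounds than are shown below. What is called first, only, known or untested is meant among the compounds shown, and "the series" means these compounds.

Measured compounds in a functional assay on the whole organism for inhibition, with Rattus norvegicus as the target, read by cytopathic effect and paw edema, at a dose of 100 mg/kg by the oral route; a lower number here means less inhibition, a higher number more inhibition at the dose given (going by the name of the read-out):
- compound 1 `CCOC(=O)c1c(O)c2cccnc2n(-c2ccccc2)c1=O`: 15.5%
- compound 2 `O=C(NN1CCOCC1)c1c(O)c2cccnc2n(-c2ccccc2)c1=O`: -26.2%
- compound 3 `O=C(Nc1cccc([N+](=O)[O-])c1)c1c(O)c2cccnc2n(-c2ccccc2)c1=O`: 7.4%

Compound 1 gives the highest of the three numbers, but its nearest neighbour, compound 3, sits within the scatter of it; only compound 2 lies clearly apart, as the step of a number 41.7 percentage points lower from compound 1 to compound 2 (beyond the scatter) shows. Replacing ethoxy on the carbonyl carbon by (3-nitrophenyl)amino gave a number 8.1 percentage points lower from compound 1 to compound 3 (within the scatter), while (morpholin-4-yl)amino at the same place gave the large drop a number 41.7 percentage points lower from compound 1 to compound 2 (beyond the scatter); between the two amides, a number 33.6 percentage points higher from compound 2 to compound 3 (beyond the scatter).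

Compound 4 `O=C(Nc1cccnc1)c1c(O)c2cccnc2n(-c2ccccc2)c1=O` carries, on the same carbonyl carbon of the shared core, the change ((pyridin-3-yl)amino in place of ethoxy on a carbonyl carbon). Within the data shown here, of the measured steps the one from compound 1 to compound 3 is the closer match, both entering groups being amides bearing a six-membered aromatic ring; the step to compound 2 speaks against reading too much into any amide as such. A small step, if any, is therefore expected, most likely not beyond the scatter and if anything downward. For compound 4 the estimate in this assay is 8%, range -15% to 30%, meaning an expected step of a number 7.5 percentage points lower from compound 1 to compound 4 (within the scatter).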

Compound 4, a percentage reported as inhibition, in the whole organism at one dose (the size of the read-out at that dose, not a potency): 30.8%
Compound 4: middle estimate off by 22.8 percentage points, on the low side, outside the stated range (above it).
By their numbers in this assay, from the lowest: compound 2; then compounds 3 and 1 (each within the scatter of the next); then compound 4.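

In this assay, the carbonyl carbon of the shared core can carry an amide with a number clearly above that of the ester: (pyridin-3-yl)amino in place of ethoxy gives a number 15.3 percentage points higher from compound 1 to compound 4 (beyond the scatter), the first step upward from compound 1 in the series. The group on the amide-type nitrogen decides much of the outcome, as pyridin-3-yl in place of 3-nitrophenyl gives a number 23.4 percentage points higher from compound 3 to compound 4 (beyond the scatter) and pyridin-3-yl in place of morpholin-4-yl gives a number 57 percentage points higher from compound 2 to compound 4 (beyond the scatter), so a six-membered aromatic ring on that nitrogen does not by itself secure the higher number. Nothing measured here accounts for these differences.

Whether the rise goes with the pyridine ring as such remains open, as the plain phenylamino amide and the pyridin-2-yl and pyridin-4-yl amides do not appear among these compounds. Also open, on these data alone, is how a free carboxylic acid or a simple ethylamino amide would read at the same carbonyl carbon.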